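From Chloro to Bromo: Expected Lipophilicity of Compound 4

The source may report more compounds than this note shows. Statements on the series, on what has been measured and on what is new or still open speak of the compounds shown alone.

Compound 1 `S=C(N/N=C/c1ccc(Oc2ccc(Cl)cc2)cc1)Nc1ccc(Br)cc1`: 6.24
Compound 2 `S=C(N/N=C/c1ccc(Oc2ccc(Br)cc2)cc1)Nc1ccc(Br)cc1`: 6.53
Compound 3 `Fc1ccc(Oc2ccc(/C=N/NC(=S)Nc3ccc(Cl)cc3)cc2)cc1`: 5.84

In a physicochemical assay for lipophilicity, in phosphate buffer, measured as octanol-water partition, with a stated time of 24 h (on this read-out higher numbers stand for higher lipophilicity and lower numbers for lower lipophilicity), compound 3 stands lowest of the three numbers; compound 1 lies higher by a margin beyond the scatter, and compound 2 lies higher still, also beyond the scatter. Compound 4 `Fc1ccc(Oc2ccc(/C=N/NC(=S)Nc3ccc(Br)cc3)cc2)cc1` differs from compound 3 in one place: bromo in place of chloro on an aromatic carbon. Among the measured compounds shown here, one measured step bears directly on this change, namely a number 0.29 log units higher from compound 1 to compound 2 (within the scatter), the same exchange carried out on another pair. For compound 4 a step of similar size upward is therefore expected, a number 0.29 log units higher from compound 3 to compound 4 (within the scatter), a change that would sit within the scatter. Compound 4 is accordingly estimated at 6.13, with a range from 5.8 to 6.45.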

Compound 4, partition coefficient: 5.82
Compound 4: middle estimate off by 0.31 log units, on the high side, and the stated range covers the measured number.
By their numbers in this assay, from the lowest: compounds 4 and 3 (each within the scatter of the next); then compounds 1 and 2 (each within the scatter of the next).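

At the (4-chlorophenyl)amino place, bromo in place of chloro reads in this assay as a number 0.02 log units lower from compound 3 to compound 4 (within the scatter) and, like the earlier exchange at another place, stays within the scatter. At that other halogen place, fluoro gives a number 0.71 log units lower from compound 2 to compound 4 (beyond the scatter) when it replaces bromo and a number 0.42 log units lower from compound 1 to compound 4 (beyond the scatter) when it replaces chloro, both beyond the scatter. No evidence here accounts for this difference in step size. The compounds shown leave open how an amine or a carboxylic acid at either place would read, and whether the fluoro step would keep its size with other halogen partners.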